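The source may report more compounds than this note shows. Statements on the series, on what has been measured and on what is new or still open speak of the compounds shown alone.

Measured so far:
compound 1, `CSc1cc(C)nc(NC(=S)NC(=O)c2c(-c3ccc(Cl)cc3Cl)noc2C)n1`, 47.1%
compound 2, `Cc1cc(Cl)nc(NC(=S)NC(=O)c2c(-c3ccc(Cl)cc3Cl)noc2C)n1`, 48.7%
compound 3, `COc1cc(Cl)nc2n/c(=N/C(=O)c3c(-c4ccc(Cl)cc4Cl)noc3C)sn12`, 40.8%

All three were run in a functional assay on the whole organism (strain L.) for inhibition, with Echinochloa crus-galli as the target, with a stated time of 72 h, tested at 100 mg/L; a lower number here means less inhibition of growth, a higher number more inhibition of growth at the concentration tested. Compound 2 gives 48.7% and compound 1 gives 47.1%; the change between them is methylsulfanyl in place of chloro on an aromatic carbon, and the step it made is a number 1.6 percentage points lower from compound 2 to compound 1 (within the scatter). Compound 3 gives 40.8%, which is within the scatter of both other numbers. The difference between the core of compound 3 and the core of compound 2 is not broken down here.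

Compound 4, `COc1cc(SC)nc2n/c(=N/C(=O)c3c(-c4ccc(Cl)cc4Cl)noc3C)sn12`, has not yet been measured in this assay . It differs from compound 3 by methylsulfanyl in place of chloro on an aromatic carbon. Among the measured compounds shown here, this is the same kind of change as the one from compound 2 to compound 1, but the surroundings of the place are not identical: in compound 4 the ring is part of a fused or bridged system of two rings, the carbon is meta to a fused ring, meta to a methoxy group and para to a fused ring, whereas in compound 1 the carbon is meta to a large group and meta to a methyl group.

For the measured compounds named here, because the one measured example of this change, a number 1.6 percentage points lower from compound 2 to compound 1 (within the scatter), stayed within the scatter, the step of a number 0.8 percentage points lower from compound 3 to compound 4 (within the scatter) is expected to be small as well. Compound 4 is accordingly estimated at 40%, with a likely range from 27% to 53%.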

Compound 4, percent growth inhibition at one concentration: 55.6%
Beside the measured number, compound 4's estimate is 15.6 percentage points below it, outside the stated range (above it).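

In this assay, methylsulfanyl in place of chloro on an aromatic carbon gives a number 14.8 percentage points higher from compound 3 to compound 4 (beyond the scatter) on the core of compound 3, against a number 1.6 percentage points lower from compound 2 to compound 1 (within the scatter) on the core of compound 2. The change therefore does not carry over as a fixed step between these two cores: the same change on two cores in this assay, a number 1.6 percentage points lower (within the scatter) from compound 2 to compound 1 and a number 14.8 percentage points higher (beyond the scatter) from compound 3 to compound 4, 16.4 percentage points apart, beyond the scatter of two such steps

This shows that, in these four compounds, the size of the step depends on the core it is made on. With a single pair per core, it does not show which feature of the core is responsible, or what the same change would do on a third core, and a read-out at one concentration says nothing about behaviour at other concentrations.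

On the core of compound 3, the compounds shown hold only chloro and methylsulfanyl at this carbon, so it stays open whether an amine or a longer chain on the sulfur would match or differ from compound 4 at 55.6%. Also open, going by these compounds, is whether the larger step would persist if the methoxy group on this core gave way to an amine.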